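The source may report more compounds than this note shows. Statements on the series, on what has been measured and on what is new or still open speak of the compounds shown alone.

Compound 3 `Cc1ccc(S(=O)(=O)n2c(Cc3cn(C)c4ccccc34)c(C)c3ccccc32)cc1` is the starting point of this step. For the measured compounds named here, in an assay on HepG2 cells for inhibition of Proprotein convertase subtilisin/kexin type 9 (Homo sapiens), read by AlphaLISA, with a stated time of 48 h (on this read-out higher numbers stand for weaker inhibition and lower numbers for stronger inhibition), compound 3 gives 1500 nM, the lowest of the three numbers measured so far. Compound 2 `Cc1ccc(S(=O)(=O)n2c(Cc3c[nH]c4c(Cl)cccc34)c(C)c3ccccc32)cc1` gives 2300 nM, and the difference between them, a 1.5-fold lower number from compound 2 to compound 3 (0.19 log units; within the scatter), exchanges one group on a saturated chain carbon and lies within the scatter, so the two cannot be told apart on this read-out. Compound 1 `Cc1ccc2[nH]cc(Cc3cc4ccccc4[nH]3)c2c1` gives 5600 nM, and its gap to compound 3 is beyond the scatter.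

Compound 4 `Cc1ccc(S(=O)(=O)n2c(Cc3cn(C)c4ccccc34)c(C(C)C)c3ccccc32)cc1` has not been measured. It differs from compound 3 in one place: isopropyl in place of methyl on an aromatic carbon. Going by the values given here, no measured step touches this position. Among the compounds with values here, the only step measured so far, a 1.5-fold lower number from compound 2 to compound 3 (0.19 log units; within the scatter), alters a different part of the molecule and was itself within the scatter, so it gives no guidance on the size or direction of the present change. Compound 4 is therefore expected to give a number close to that of compound 3. Within the data shown here, the step of no change at the digits printed from compound 3 to compound 4 (within the scatter) is estimated to stay within the scatter, with a wide margin on both sides because nothing measured so far speaks to this change. In this assay compound 4 is estimated at 1500 nM, within a range from 500 nM to 4500 nM.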

Compound 4, half-maximal inhibitory concentration: 1100 nM
For compound 4 the middle estimate is 1.4-fold (0.13 log units) above the measured one; measured number inside the range.
By their numbers in this assay, from the lowest: compounds 4, 3 and 2 (each within the scatter of the next, the first and the last beyond it); then compound 1.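

In this assay, exchanging methyl for isopropyl gives a 1.4-fold lower number from compound 3 to compound 4 (0.13 log units; within the scatter), so the two compounds cannot be told apart on this read-out. For the compounds shown here, this is the first measured change at this position, an aromatic carbon of the five-membered aromatic ring, two ring bonds from the ring nitrogen and two ring bonds from the ring atom that bears the (4-methylphenyl)sulfonyl group. It shows that going from 1 heavy atom to 3 heavy atoms here leaves the number within the scatter, although a single pair of compounds cannot establish a trend, and nothing shown here accounts for this result.

The compounds shown leave open whether a larger or different group at this position, such as tert-butyl, a phenyl ring, an amine or a carboxylic acid, would also keep the number within the scatter of compound 3. Going by these compounds, it also remains open whether the exchange of methyl for isopropyl would read the same way with 7-chloro-1H-indol-3-yl, the group carried by compound 2, in place of 1-methyl-1H-indol-3-yl on the saturated chain carbon.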